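Notes on oral exposure: compound 3 and its mirror image

The compounds below may be only part of what the source reports. "The series", "measured", "known", "first", "only" and "open" are said of these compounds alone.

Three compounds in the series have numbers in an in vivo ADME assay on the whole organism for pharmacokinetics, with Cynomolgus monkey (Macaca fascicularis) as the target, at a dose of 1 mg/kg by the oral route; a higher number here means that a larger share of the oral dose reaches the circulation, a lower number that a smaller share of the oral dose reaches the circulation. Compound 1 `CS(=O)(=O)Nc1ccc2c(c1)S(=O)(=O)N=C(C1=C(O)[C@H]3CCC[C@H]3N(Cc3ccc(F)c(F)c3)C1=O)N2` gives 12% in this assay. Compound 2 `CS(=O)(=O)Nc1ccc2c(c1)S(=O)(=O)N=C(c1c(O)c3cccn3n(Cc3ccc(F)cc3)c1=O)N2` gives 1% in this assay. Compound 3 `CS(=O)(=O)Nc1ccc2c(c1)S(=O)(=O)N=C(C1=C(O)[C@H]3CCCC[C@H]3N(Cc3ccc(F)cc3)C1=O)N2` gives 12% in this assay. On these numbers compound 3 stands level with compound 1 at the digits shown, the two together the highest of the three; the gap to compound 1 is within the scatter, while the gap to compound 2 lies beyond the scatter, compound 2 being the lower of the pair.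

Compound 4 `CS(=O)(=O)Nc1ccc2c(c1)S(=O)(=O)N=C(C1=C(O)[C@@H]3CCCC[C@@H]3N(Cc3ccc(F)cc3)C1=O)N2` has not been measured in this assay. The change from compound 3 to compound 4 is this: the two compounds have the same atoms and bonds and differ only in configuration as drawn: 2 of 2 stereo elements differ (all stereocentres are inverted: mirror images); a stereocentre at a saturated ring carbon is drawn S in compound 3 and R in compound 4; a stereocentre at a saturated ring carbon is drawn R in compound 3 and S in compound 4. Going by the values given here, no step between measured compounds involves an inversion of configuration, so nothing here anchors the size or direction of such a step. The expectation for compound 4 therefore rests on compound 3 alone: the step of a number 2 percentage points lower from compound 3 to compound 4 (within the scatter) is expected to be small, with no direction beyond the scatter claimed. Among the compounds with values here, compound 4 is estimated at 10% in this assay, within a range from 2% to 25%, kept wide since mirror images may behave differently and no measured pair shows by how much.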

Compound 4, oral bioavailability: 6%
Beside the measured number, compound 4's estimate is 4 percentage points above it; low and high end bracket the measured number.
By their numbers in this assay, from the lowest: compounds 2, 4, 1 and 3 (each within the scatter of the next, the first and the last beyond it).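

In this assay, the series now holds its first measured inversion of configuration, and this inversion gives a number 6 percentage points lower from compound 3 to compound 4 (within the scatter). With both stereocentres at the saturated ring carbons inverted, the two mirror images are therefore not separated beyond the usual scatter, and this pair gives no ground for preferring one configuration over the other. This is a clean reading of configuration at this position, since no other structural change has to be weighed against it: the fact that compounds 3 and 4 differ only in the configuration as drawn.

A single mirror-image pair leaves open whether the same inversion would also stay within the scatter in compound 1, with its different saturated ring and benzyl substitution, and the numbers do not tell which processes set the oral exposure of either configuration. From the compounds shown here alone, it is also open whether compound 3 and compound 4 would stay within the scatter of each other if both carried an added group such as an amine or a carboxylic acid, which would show whether the configuration matters more in a changed setting.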